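The source may hold more compounds than are shown below. What is called first, only, known or untested is meant among the compounds shown, and "the series" means these compounds.

Compound 2 `O=C(NC(c1ccccc1)c1ccccc1)[C@@H]1CCCN1C(=S)NCc1ccccc1Cl` is one of two entries in an assay on membranes from brain (Oryctolagus cuniculus) for binding affinity to Substance-P receptor (Homo sapiens) (on this read-out lower numbers stand for stronger inhibition and higher numbers for weaker inhibition), where compound 2 gives 170 nM. The other entry, compound 1 `COc1ccccc1C/N=C(\S)N1CCC[C@H]1C(=O)NC(c1ccccc1)c1ccccc1`, gives in this assay 330 nM, and the two numbers sit within the usual scatter of each other. Compound 3 `O=C(NC(c1ccccc1)c1ccccc1)[C@@H]1CCCN1C(=S)NCc1ccccc1Br` carries bromo in place of chloro on an aromatic carbon, a change that swaps one halogen for another at the same place on the ring. Among the compounds with values here, with no measured step of this kind among the compounds at hand, a shift beyond the scatter is not expected in either direction. Compound 3 is estimated at 150 nM, with a range of 60 nM to 400 nM, which amounts to an expected step of a 1.1-fold lower number from compound 2 to compound 3 (0.05 log units; within the scatter).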

Compound 3, inhibition constant: 1700 nM
Estimate against measurement, compound 3: 11-fold (1.05 log units) below; the measured number lies above the stated range.
By their numbers in this assay, from the lowest: compounds 2 and 1 (each within the scatter of the next); then compound 3.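

In this assay, exchanging one halogen for another on this aromatic carbon is not a neutral change: bromo in place of chloro gives a 10-fold higher number from compound 2 to compound 3 (1.00 log units; beyond the scatter). The earlier compounds shown here offered no measured step, so only now is it clear that this place can respond sharply to a change of a single heavy atom. Nothing at hand bears on why the number rises. Going by these compounds, what stays open is whether a fluoro or a methyl group on this aromatic carbon would give a number nearer that of compound 2 or that of compound 3.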